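Swapping an Aryl Amide for a Piperazinyl Acetamide

The source may report more compounds than this note shows. Statements on the series, on what has been measured and on what is new or still open speak of the compounds shown alone.

For the measured compounds named here, compound 2 `O=C(c1ccccc1Cl)N1N=C(c2cc3ccccc3oc2=O)CC1c1ccccc1` gives 6370 nM in a functional assay on PC-3 cells (Homo sapiens) for cytotoxicity, read by MTT assay, with a stated time of 48 h (a higher number here means a weaker inhibitor, a lower number a stronger inhibitor), the lower of the two numbers measured so far. Compound 1 `CCC(=O)N1N=C(C)CC1c1cc(Br)cc(Br)c1O` gives 28600 nM in this assay, and the gap between the two lies beyond the usual scatter; they share no single-point change, so only their values can be set side by side. Compound 3 `CN1CCN(CC(=O)N2N=C(c3cc4ccccc4oc3=O)CC2c2ccccc2)CC1` keeps the core of compound 2 and differs by (4-methylpiperazin-1-yl)methyl in place of 2-chlorophenyl on a carbonyl carbon. Going by the values given here, no measured pair tests this change, so the direction is open; a modest step toward a weaker inhibitor is expected, a 1.4-fold higher number from compound 2 to compound 3 (0.15 log units; within the scatter). Compound 3 is estimated at 9000 nM, within a range from 3000 nM to 27000 nM.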

Compound 3, half-maximal inhibitory concentration: 25800 nM
Beside the measured number, compound 3's estimate is 2.9-fold (0.46 log units) below it; measured number inside the range.
By their numbers in this assay, from the lowest: compound 2; then compounds 3 and 1 (each within the scatter of the next).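

For the compounds shown here, this step is the first reading at this place, on a carbonyl carbon whose other neighbour is the amide-type nitrogen in a ring: (4-methylpiperazin-1-yl)methyl in place of 2-chlorophenyl gives a 4.1-fold higher number from compound 2 to compound 3 (0.61 log units; beyond the scatter) in this assay on the shared core. The group here therefore changes the reading, and of these two, 2-chlorophenyl gives the stronger inhibitor. Nothing available explains the difference. Still open, on these data alone, is whether the chlorine or the ring accounts for it, and how an unsubstituted phenyl or a morpholin-4-ylmethyl group would read at this place.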